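The source may hold more compounds than are shown below. What is called first, only, known or untested is meant among the compounds shown, and "the series" means these compounds.

Of the compounds shown here, three built on the same core have been measured in an ADME assay on Caco-2 cells (Homo sapiens) for permeability, read by LC-MS, in the apical to basolateral direction, with a stated time of 60 min, at pH 6.5; on this read-out lower numbers stand for lower permeability and higher numbers for higher permeability. Compound 1 `O=C(NCc1cc(Cl)ccc1-n1cnnn1)[C@@H]1C[C@@H]2C[C@@H]2N1C(=O)[C@H](O)Cc1ccccn1` gives 1.2 10^-6 cm/s. Compound 2 `O=C(NCc1cc(Cl)ccc1-n1cnnn1)[C@@H]1[C@H]2C[C@H]2CN1C(=O)[C@H](O)c1ccccc1` gives 12 10^-6 cm/s. Compound 3 `O=C(NCc1cc(Cl)ccc1-n1cnnn1)[C@@H]1[C@@H]2C[C@@H]2CN1C(=O)[C@H](O)c1ccccc1` gives 2.2 10^-6 cm/s, the second highest of the three numbers; the value of compound 1 lies within the scatter of it, while the value of compound 2 stands beyond the scatter above it. Among the measured compounds shown here, the only step between measured compounds that differ in one place is a 5.5-fold lower number from compound 2 to compound 3 (0.74 log units; beyond the scatter), which rests on (the fact that compounds 2 and 3 differ only in the configuration as drawn).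

Compound 4 `O=C(NCc1cc(Cl)ccc1-n1cnnn1)[C@@H]1[C@@H]2C[C@@H]2CN1C(=O)[C@H](O)c1ccccc1F` differs from compound 3 by fluoro in place of hydrogen on an aromatic carbon. For the measured compounds named here, no measured step covers this kind of change: the single step in hand concerns configuration alone and offers no guide to the direction or size of a fluoro substitution. Compound 4 is therefore expected to show no step beyond the scatter in this assay, the estimated step being a 1.1-fold higher number from compound 3 to compound 4 (0.06 log units; within the scatter). Compound 4 is estimated at 2.5 10^-6 cm/s, with a range from 1.1 10^-6 cm/s to 5.5 10^-6 cm/s.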

Compound 4, apparent permeability: 2.3 10^-6 cm/s
Compound 4: the middle estimate sits 1.1-fold (0.04 log units) above what was measured; low and high end bracket the measured number.
By their numbers in this assay, from the lowest: compounds 1, 3 and 4 (each within the scatter of the next); then compound 2.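

In this assay, fluoro in place of hydrogen on an aromatic carbon, ortho to a large group, gives a 1.0-fold higher number from compound 3 to compound 4 (0.02 log units; within the scatter), so the change from phenyl to 2-fluorophenyl leaves the two numbers indistinguishable on the configuration of compound 3. Among the compounds shown here, this is the first measured change at this aromatic ring, and it contrasts with the configurational change, which gave a 5.5-fold lower number from compound 2 to compound 3 (0.74 log units; beyond the scatter) and stands beyond the scatter. Nothing in the available evidence bears on why the fluoro change produces a step within the scatter.

Whether a methoxy group, a nitrile or an amine at this same place would also remain within the scatter is open. Going by these compounds, it is equally open whether fluoro would behave the same way on the configuration of compound 2.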